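This account rests on a few compounds, and the source may have more. Where it says the series, first, only, none or still open, it means among the compounds named here.

Compound 1 `CCc1ccc(NC(=S)N/N=C/c2cccs2)cc1` is the anchor of this set. In a functional assay on NCI/ADR-RES cells (Homo sapiens) for inhibition, read by sulforhodamine B assay, with a stated time of 48 h (on this read-out lower numbers stand for stronger inhibition of growth and higher numbers for weaker inhibition of growth), compound 1 gives > 100000 nM, which is a limit of the assay rather than a number. Compound 2 `S=C(N/N=C/c1cccs1)Nc1cccnc1` in this assay gives > 100000 nM, again a limit. Compound 3 `C=CCNC(=S)N/N=C/c1cccs1` in this assay gives > 100000 nM, also a limit. Where compound 1 stands is therefore fixed only from one side, as every value so far sits at the limit of > 100000 nM in this assay, at which 3 of the 3 values shown sit. Compound 4 `S=C(N/N=C/c1cccs1)Nc1ccc(Br)cc1` has not been run. It differs from compound 1 by bromo in place of ethyl on an aromatic carbon. Within the data shown here, with no measured step between any two compounds, nothing points to a step beyond the usual scatter; the expected step that the limit leaves unreadable from compound 1 to compound 4 is taken as none of note. Compound 4 is estimated in this assay at 150000 nM, within 40000 nM to 500000 nM, most likely reported again as a limit.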

Compound 4, concentration for 50% growth inhibition: 1700 nM
The estimate for compound 4 lay 88-fold (1.95 log units) above the measured number, outside the stated range (below it).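

At this position, on an aromatic carbon para to a large group, bromo in place of ethyl gives an at least 58-fold lower number from compound 1 to compound 4 (1.76 log units; beyond the scatter) in this assay. Among these compounds, the position therefore responds to a single change of group, which the earlier compounds could not show. Compound 4 is the only one shown to come off the limit: the limit of > 100000 nM in this assay, at which 3 of the 4 values shown sit.

As far as these compounds go, whether chloro, methoxy or an amine on this carbon would read like bromo or like ethyl stays open. Among the compounds shown here, also open is whether bromo keeps this result on the shared core with a different aromatic ring, such as the one in compound 2.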